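Adding a methoxy group on two related cores: solubility

The source may hold more compounds than are shown below. What is called first, only, known or untested is meant among the compounds shown, and "the series" means these compounds.

Three compounds have been measured in a physicochemical assay for solubility, read by chemiluminescence, measured as kinetic solubility; a lower number here means a less soluble compound, a higher number a more soluble compound:

Compound 1 `Cc1cc(C)cc(NC(=O)Cn2ccc(=O)c3ccccc32)c1` gives 34000 nM in this assay.
Compound 2 `Cc1cc(C)cc(NC(=O)COc2ccnc3ccccc23)c1` gives 59000 nM in this assay.
Compound 3 `COc1ccc2nccc(OCC(=O)Nc3cc(C)cc(C)c3)c2c1` gives 51000 nM in this assay.

Compound 1 and compound 2 are built from the same atoms joined differently; how their two cores differ is not broken down here, and their two values sit within the usual scatter of one another, so nothing can be read into the gap between them.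

Compound 2 and compound 3 share a core and differ in a single spot: methoxy in place of hydrogen on an aromatic carbon. In this assay that change made a 1.2-fold lower number from compound 2 to compound 3 (0.06 log units; within the scatter), so the added methoxy group left the solubility essentially unchanged on that core.

Compound 4 `COc1ccc2c(c1)c(=O)ccn2CC(=O)Nc1cc(C)cc(C)c1` has not yet been measured. It stands to compound 1 exactly as compound 3 stands to compound 2: methoxy in place of hydrogen on an aromatic carbon. The two place descriptions match word for word, so this is the same change, now made on the core of compound 1.

Among the compounds with values here, with only one earlier example of this change, the expectation rests on compound 1 and on the step from compound 2 to compound 3 being within the scatter. For compound 4 the step of a 1.1-fold lower number from compound 1 to compound 4 (0.04 log units; within the scatter) in this assay is therefore expected to be small. Compound 4 is estimated at 31000 nM in this assay, with a likely range from 15000 nM to 62000 nM.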

Compound 4, solubility: 30000 nM
Compound 4: the middle estimate sits 1.0-fold (0.01 log units) above what was measured; the range from low to high includes it.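

In this assay, methoxy in place of hydrogen on an aromatic carbon gives a 1.1-fold lower number from compound 1 to compound 4 (0.05 log units; within the scatter), and the same change on the other core gives a 1.2-fold lower number from compound 2 to compound 3 (0.06 log units; within the scatter), so on both cores the step lies within the usual scatter of repeated measurements. This shows that the result carried over between these two cores: a step too small to read on one core was also too small to read on the other, but it does not show that the methoxy group never matters in this series, as two pairs of compounds are a narrow base and a small real shift could stay hidden inside the scatter. Nothing measured here gives a reason for this outcome.

The compounds shown leave open whether a different group on the same aromatic carbon, such as an amine or a carboxylic acid, would give a step beyond the scatter, and whether such a step would then carry from one core to the other as this one did. They also leave open what a longer chain in place of the methoxy group, such as ethoxy, would do on either core.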